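Replacing the Diethylaminoethyl Amide with a Hydroxymethylethyl Amide

This account rests on a few compounds, and the source may have more. Where it says the series, first, only, none or still open, it means among the compounds named here.

Compound 1 `CCn1c(C(=O)NCc2ccc(OC)cc2)ccc1C(CC)(CC)c1ccc(C#CC(O)(CC)CC)c(C)c1` gives > 50000 nM in a functional assay on MCF7 cells (Homo sapiens) for antiproliferative activity, read by MTT assay, with a stated time of 72 h (on this read-out lower numbers stand for stronger inhibition and higher numbers for weaker inhibition), which is a limit of the assay and not a number.
Compound 2 `CCN(CC)CCNC(=O)c1cc(C(CC)(CC)c2ccc(C#CC(O)(CC)CC)c(C)c2)cn1CC` gives 1800 nM in this assay.

Compound 2 therefore holds the only number shown in this assay; the other value recorded is the limit of > 50000 nM in this assay, at which 1 of the 2 values shown sits, a limit rather than a measurement. Going by the values given here, the two measured compounds differ in more than one place, so no single step between them can be read. Among the compounds with values here, their values show only that compound 1 stays at the limit while compound 2 is measurable.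

Compound 3 `CCn1cc(C(CC)(CC)c2ccc(C#CC(O)(CC)CC)c(C)c2)cc1C(=O)N[C@@H](C)CO` keeps the core of compound 2 and changes only the amide substituent: 1-(hydroxymethyl)ethyl in place of 2-(diethylamino)ethyl on an amide-type nitrogen. The account follows this step from compound 2 to compound 3. Within the data shown here, with no measured step of the same kind to lean on, the expected change is modest and toward weaker inhibition, estimated as a 2.8-fold higher number from compound 2 to compound 3 (0.44 log units; beyond the scatter), a shift larger than the usual scatter but not by much. On that basis compound 3 is expected to give about 5000 nM in this assay, with a plausible range from 1500 nM to 20000 nM.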

Compound 3, half-maximal inhibitory concentration: 1910 nM
Estimate against measurement, compound 3: 2.6-fold (0.42 log units) above; the range from low to high includes it.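

Going by these compounds alone, the change to 1-(hydroxymethyl)ethyl in place of 2-(diethylamino)ethyl on the amide-type nitrogen gives a 1.1-fold higher number from compound 2 to compound 3 (0.03 log units; within the scatter) in this assay, the first step that can be read in one place. In this pair, the substituent on that nitrogen can go from 7 heavy atoms to 4 heavy atoms, lose its diethylamino nitrogen and gain a hydroxyl-bearing chain with 1 defined stereocentre, and the read-out does not move beyond the scatter. Nothing measured here gives a reason for this result.

Going by these compounds, whether the opposite stereocentre of 1-(hydroxymethyl)ethyl, a carboxylic acid or a longer chain on this nitrogen would leave the read-out as it stands remains open, since this single pair cannot show how far the tolerance extends. Compound 1 gives > 50000 nM as a limit and not a number, and it differs from the other compounds in more than one place, so steps to it cannot be read.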